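The compounds below may be only part of what the source reports. "The series", "measured", "known", "first", "only" and "open" are said of these compounds alone.

Measured compounds:
- compound 1 `Cc1cc(C)c(CN2CCc3c(Cl)cc([C@@H](CO)[C@@H]4CCCO4)c(Cl)c3C2=O)c(=O)[nH]1`: 1220 nM
- compound 2 `COc1cc(C)[nH]c(=O)c1CN1CCc2c(Cl)cc([C@@H](O)C3COC3)c(Cl)c2C1=O`: 10600 nM
- compound 3 `COc1cc(C)[nH]c(=O)c1CN1CCc2c(Cl)cc([C@H](O)C3COC3)c(Cl)c2C1=O`: 108 nM

In a functional assay on KARPAS-422 cells (Homo sapiens) for antiproliferative activity, read by resazurin assay, with a stated time of 72 h (on this read-out higher numbers stand for weaker inhibition and lower numbers for stronger inhibition), compound 1 gives 1220 nM, the second highest of the three numbers. Its nearest neighbour is compound 2, which in this assay gives 10600 nM; furthest from it stands compound 3, which in this assay gives 108 nM.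

The compound not yet measured is compound 4 `Cc1cc(C)c(CN2CCc3c(Cl)cc([C@H](CO)[C@@H]4CCCO4)c(Cl)c3C2=O)c(=O)[nH]1`. Relative to compound 1 the change is the two compounds have the same atoms and bonds and differ only in configuration as drawn: 1 of 2 stereo elements differ; a stereocentre at a saturated chain carbon is drawn S in compound 1 and R in compound 4.

Among the measured compounds shown here, one measured step bears on this: a 98-fold lower number from compound 2 to compound 3 (1.99 log units; beyond the scatter). For the measured compounds named here, that step is attributed to a change in configuration alone, because the fact that compounds 2 and 3 differ only in the configuration as drawn is the only way compounds 2 and 3 differ. Compound 1 and compound 4 likewise differ only in configuration at a saturated chain carbon, so a large step in this assay is expected, and since compound 1 sits well above compound 3, the expected direction is toward a lower number.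

Compound 4 is therefore estimated at 100 nM, ranging from 20 nM to 800 nM, which is expected to amount to a 12-fold lower number from compound 1 to compound 4 (1.09 log units; beyond the scatter).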

Compound 4, half-maximal inhibitory concentration: 57 nM
Beside the measured number, compound 4's estimate is 1.8-fold (0.24 log units) above it, within the range that was stated.
By their numbers in this assay, from the lowest: compounds 4 and 3 (each within the scatter of the next); then compound 1; then compound 2.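

In this assay, inverting the saturated chain carbon alone gives a 21-fold lower number from compound 1 to compound 4 (1.33 log units; beyond the scatter), while the second stereo element stays as drawn. This is a second pair with a large step at such a carbon, alongside a 98-fold lower number from compound 2 to compound 3 (1.99 log units; beyond the scatter), and in both pairs the lower number belongs to the compound drawn R. The step in the new pair can be assigned to this one stereocentre because nothing else changes: the fact that compounds 1 and 4 differ only in the configuration as drawn

The compounds shown leave open what the other stereo element contributes, as no pair here differs at that centre. They also leave open how this assay would respond if an amine or a carboxylic acid replaced the hydroxyl group at this chain carbon, in either configuration.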